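Oxime ether series: tert-butyl to ethyl on the oxime oxygen

A few compounds are considered here, and "the series" means these few. Any claim that something is new, unique, unknown or untested is made for them only; others in the source may bear on it.

Measured so far:
compound 1 `O=c1[nH]/c(=N\OCCCc2ccccc2)ccn1[C@@H]1O[C@H](COP(=O)(O)OP(=O)(O)OP(=O)(O)O)[C@@H](O)[C@H]1O` — 640 nM
compound 2 `CC(C)(C)O/N=c1/ccn([C@@H]2O[C@H](COP(=O)(O)OP(=O)(O)OP(=O)(O)O)[C@@H](O)[C@H]2O)c(=O)[nH]1` — 1500 nM

In an in vitro functional assay on 1321-N1 cells for agonist activity at P2Y purinoceptor 2 (Homo sapiens), read by scintillation proximity assay and inositol phosphate accumulation, with a stated time of 30 min (a lower number here means that less compound is needed, a higher number that more compound is needed for the effect), compound 1 gives 640 nM and compound 2 gives 1500 nM. Among the measured compounds shown here, compound 2 stands at the higher of the two numbers in this assay; the only measured step, a 2.3-fold higher number from compound 1 to compound 2 (0.37 log units; beyond the scatter), puts it beyond the scatter from compound 1, so more of compound 2 is needed for the same effect.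

Compound 3 `CCO/N=c1/ccn([C@@H]2O[C@H](COP(=O)(O)OP(=O)(O)OP(=O)(O)O)[C@@H](O)[C@H]2O)c(=O)[nH]1` is the next member. It differs from compound 2 in one place: ethyl in place of tert-butyl on an oxygen. For the measured compounds named here, the only step that bears on this change is a 2.3-fold higher number from compound 1 to compound 2 (0.37 log units; beyond the scatter), where a larger chain on the same oxygen gave the lower number and the compact tert-butyl the higher one. Going from tert-butyl to ethyl reduces the group further rather than restoring the longer chain, so no gain is expected; the step is estimated to be small and at most a modest rise in this assay, read as a 1.3-fold higher number from compound 2 to compound 3 (0.12 log units; within the scatter). For compound 3 the expected value in this assay is 2000 nM, with a range of 700 nM to 6000 nM.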

Compound 3, half-maximal effective concentration: 817 nM
Compound 3: middle estimate off by 2.4-fold (0.39 log units), on the high side, and the stated range covers the measured number.
By their numbers in this assay, from the lowest: compounds 1, 3 and 2 (each within the scatter of the next, the first and the last beyond it).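

In this assay, replacing tert-butyl with ethyl on the oxime oxygen gives a 1.8-fold lower number from compound 2 to compound 3 (0.26 log units; within the scatter), and removing the benzyl from the 3-phenylpropyl chain gives a 1.3-fold higher number from compound 1 to compound 3 (0.11 log units; within the scatter), so neither step separates compound 3 from its neighbour. Only a 2.3-fold higher number from compound 1 to compound 2 (0.37 log units; beyond the scatter) lies beyond the scatter, which means that compound 3, with the smallest of the three groups, cannot be placed apart from either compound 1 or compound 2. The earlier pair alone suggested that the long 3-phenylpropyl chain gave the lower number, but compound 3 goes against any simple reading by chain length, and no available evidence accounts for the values at this position.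

The compounds shown leave open whether the distance between compound 1 and compound 2 follows from branching or from overall group size, a question that isopropyl or n-butyl on the same oxygen would bear on. Also open, on these data alone, is how the series responds to an amine or a carboxylic acid at the end of a longer chain on this oxygen.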